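The source may hold more compounds than are shown below. What is called first, only, known or untested is meant among the compounds shown, and "the series" means these compounds.

Measured compounds: compound 1 `CCCCCc1ccc(Nc2ccc3c(c2)C(=O)N(C2CCC(=O)NC2=O)C3=O)cc1` with 12%; compound 2 `C=C(OCC)c1ccc(Nc2cccc3c2C(=O)N(C2CCC(=O)NC2=O)C3=O)cc1` with 10%.

In an assay on FRT-Jurkat cells for inhibition of nuclear factor NF-kappa-B complex (Homo sapiens), read by flow cytometry, with a stated time of 24 h, tested at 10 uM (on this read-out lower numbers stand for less inhibition and higher numbers for more inhibition at the one concentration tested (going by the name of the read-out)), compound 1 gives 12% and compound 2 gives 10%; these two numbers lie within the usual scatter of each other, so compound 2 stands level with compound 1, both at the low end of the scale. Compound 3 `CCCc1ccc(Nc2cccc3c2C(=O)N(C2CCC(=O)NC2=O)C3=O)cc1` differs from compound 2 in one place: propyl in place of 1-ethoxyethenyl on an aromatic carbon. Within the data shown here, no measured pair follows this change, so no step beyond the scatter is expected in this assay, in either direction. Compound 3 is therefore estimated at 12%, between 0% and 30%. The step of a number 2 percentage points higher from compound 2 to compound 3 (within the scatter) that this estimate means is expected to stay within the scatter.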

Compound 3, a percentage reported as inhibition, at one concentration (the size of the read-out at that concentration, not a potency): 23%
Compound 3: middle estimate off by 11 percentage points, on the low side; the measured number falls inside the stated range.
By their numbers in this assay, from the lowest: compounds 2 and 1 (each within the scatter of the next); then compound 3.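

In this assay, propyl in place of 1-ethoxyethenyl gives a number 13 percentage points higher from compound 2 to compound 3 (beyond the scatter), so the group on this aromatic carbon, para to a large group, can shift the read-out. Among these compounds, the earlier compounds offered no comparison differing in one place, so this is the first such step. No measurement at hand explains it.

On these data alone, since propyl differs from 1-ethoxyethenyl in chain length, oxygen and double bond together, which of these matters stays open. As far as these compounds go, whether a butyl chain or an amine on the same carbon would raise or lower the number is also open.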